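This account rests on a few compounds, and the source may have more. Where it says the series, first, only, none or still open, it means among the compounds named here.

Compound 1 `Cc1ccc(NC(=O)N[C@@H](C)c2ccccc2)cc1`: 100%
Compound 2 `CCCCCc1ccc(NC(=O)N[C@@H](C)c2ccccc2)cc1`: 93%
Compound 3 `C[C@H](NC(=O)Nc1ccc(F)cc1)c1ccccc1`: 85%

In an ADME assay on the whole organism with Oryza sativa as the target, tested at 10 uM (a higher number here means a weaker effect of the compound at the concentration tested, a lower number a stronger effect), compound 3 gives 85%, the lowest of the three numbers. Its nearest neighbour is compound 2, with a number 8 percentage points lower from compound 2 to compound 3 (within the scatter); the widest gap is to compound 1, with a number 15 percentage points lower from compound 1 to compound 3 (beyond the scatter). Compound 4 `C[C@H](NC(=O)Nc1ccc(Br)cc1)c1ccccc1` differs from compound 3 by bromo in place of fluoro on an aromatic carbon. Among the measured compounds shown here, no measured step exchanges one halogen for another, so the bearing of the known data is indirect: the two steps that alter this same aromatic carbon, a number 15 percentage points lower from compound 1 to compound 3 (beyond the scatter) and a number 8 percentage points lower from compound 2 to compound 3 (within the scatter), move the number only modestly or not beyond the scatter. The step is therefore expected to be no change at the digits printed from compound 3 to compound 4 (within the scatter), within the scatter. For compound 4 the estimate is 85%, with a range from 75% to 95%.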

Compound 4, a percentage reported as activity, at one concentration (the size of the read-out at that concentration, not a potency): 96%
The estimate for compound 4 lay 11 percentage points below the measured number; the whole stated range lies below it.
By their numbers in this assay, from the lowest: compounds 3, 2, 4 and 1 (each within the scatter of the next, the first and the last beyond it).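

At this aromatic carbon, para to a large group, exchanging one halogen for another moves the number in this assay: there is a number 11 percentage points higher from compound 3 to compound 4 (beyond the scatter). Bromo does not share the lower number seen with fluoro, and its results stay close to those of the alkyl groups, with a number 3 percentage points higher from compound 2 to compound 4 (within the scatter) and a number 4 percentage points lower from compound 1 to compound 4 (within the scatter). No available evidence bears on this difference.

Chloro or iodo at the same carbon would show whether fluoro stands apart among the halogens. An amine or a hydroxyl group there would show whether the lower number requires a halogen at all.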